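The compounds below may be only part of what the source reports. "The series", "measured", "known", "first", "only" and "open" are said of these compounds alone.

Compound 1 `COc1cccc(-c2cc(-c3cc4cc(OC)ccc4[nH]3)no2)c1`: in a functional assay on COLO 320 cells (Homo sapiens) for cytotoxicity, read by WST assay, with a stated time of 72 h (a lower number here means a stronger inhibitor, a higher number a weaker inhibitor), compound 1 gives > 100000 nM, which is a limit of the assay and not a number.
Compound 2 `COc1ccc2[nH]c(-c3cc(-c4cccc(F)c4)on3)cc2c1`: in this assay compound 2 gives > 100000 nM, again a limit and not a number.
Compound 3 `Fc1ccc(-c2cc(-c3ccc4[nH]ccc4c3)on2)cc1`: in this assay compound 3 gives 13900 nM.

Going by the values given here, compound 3 stands alone as the only measured number in the set; the two other values are limits, and the limit of > 100000 nM in this assay, at which 2 of the 3 values shown sit, marks where they sit. Compound 2 and compound 1 differ by a single change, (methoxy in place of fluoro on an aromatic carbon), and the step that the two limits leave unreadable from compound 2 to compound 1 cannot be read because both ends are limits. The difference between the core of compound 2 and the core of compound 3 is not broken down here.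

Compound 4 `COc1ccc(-c2cc(-c3ccc4[nH]ccc4c3)on2)cc1` has not yet been measured in this assay. It differs from compound 3 by methoxy in place of fluoro on an aromatic carbon. This is the same kind of change as that from compound 2 to compound 1, but not the same: in compound 4 the methoxy sits para to a large group, whereas in compound 1 it sits meta to a large group. Among the compounds with values here, the one measured example of this change gives no readable size, so the step from compound 3 to compound 4 is estimated with little support. Within the data shown here, the only anchor is compound 3 with its value 13900 nM. From this anchor, a 1.4-fold higher number from compound 3 to compound 4 (0.16 log units; within the scatter) is expected to be small. Compound 4 is therefore estimated at 20000 nM, with a range from 5000 nM to 90000 nM.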

Compound 4, half-maximal inhibitory concentration: 13500 nM
Estimate against measurement, compound 4: 1.5-fold (0.17 log units) above; the range from low to high includes it.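

In this assay, methoxy in place of fluoro on an aromatic carbon, para to a large group, gives a 1.0-fold lower number from compound 3 to compound 4 (0.01 log units; within the scatter), so on the core shared by this pair the exchange has no readable effect on the number. The same kind of change on the core of compound 2 cannot be read, as both of its ends are limits of the assay and not numbers: the limit of > 100000 nM in this assay, at which 2 of the 4 values shown sit. This means there is a single readable example of the change, on one core and at one place on the ring, and it shows neither that the flat result carries over to the core of compound 1 nor that it fails to do so.

The compounds shown leave open whether any group at this place on the core of compound 4, which gives 13500 nM, would shift the number beyond the scatter, for instance an amine, a carboxylic acid or a longer chain such as butoxy in place of methoxy. They also leave open whether the fluoro and methoxy exchange has any size on the core of compound 1, which would take a partner on that core with a value that is a number and not a limit.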